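The source may report more compounds than this note shows. Statements on the series, on what has been measured and on what is new or still open speak of the compounds shown alone.

The series is followed in an assay on HEK293 cells for inhibition of acid ceramidase (Homo sapiens), read by fluorescence, with stated times of 10 min and 3 h; a lower number here means a stronger inhibitor, a higher number a weaker inhibitor. Compound 1 `CN1CCC(c2ccc3c(c2)oc(=O)n3C(=O)NCCCCc2ccccc2)CC1=O` gives 105 nM, the highest of the two numbers in hand. Compound 2 `CN1CCC(c2cc3oc(=O)n(C(=O)NCCCCc4ccccc4)c3cc2F)CC1` gives 24 nM, a lower number, and the gap between these two values lies beyond the usual scatter. Among the measured compounds shown here, no step between measured compounds differing in a single place is available. Compound 3 `CC(C)CN1CCN(c2ccc3c(c2)oc(=O)n3C(=O)NCCCCc2ccccc2)CC1` differs from compound 1 by 4-isobutylpiperazin-1-yl in place of 1-methyl-2-oxopiperidin-4-yl on an aromatic carbon. Without a comparable step to rest on, a modest move toward a lower number is expected, possibly none beyond the scatter. Compound 3 is estimated at 60 nM, within 15 nM to 250 nM. The step of a 1.8-fold lower number from compound 1 to compound 3 (0.24 log units; within the scatter) is expected to be small.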

Compound 3, half-maximal inhibitory concentration: 127 nM
The estimate for compound 3 lay 2.1-fold (0.33 log units) below the measured number; the measured number falls inside the stated range.
By their numbers in this assay, from the lowest: compound 2; then compounds 1 and 3 (each within the scatter of the next).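

In this assay, the swap on this aromatic carbon gives a 1.2-fold higher number from compound 1 to compound 3 (0.08 log units; within the scatter). The 4-isobutylpiperazin-1-yl and 1-methyl-2-oxopiperidin-4-yl groups differ in ring hetero atoms and heavy-atom count, yet this pair reads alike at this position. No measured evidence accounts for this result. Still open, from the compounds shown here alone, is whether a carboxylic acid or a primary amine on this aromatic carbon would read alike too. Going by these compounds, a longer chain in place of the isobutyl of compound 3 also remains open.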